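The source may hold more compounds than are shown below. What is called first, only, known or untested is meant among the compounds shown, and "the series" means these compounds.

Working notes on the series.

Three compounds share one core and differ only in the aryl group on the amide-type nitrogen. Compound 1 `COc1ccccc1NC(=O)NCC1(c2ccccc2)CCCCC1` gives 270 nM in an assay on microsomes from intestine for inhibition of acyl-CoA:cholesterol acyltransferase (Oryctolagus cuniculus); a higher number here means a weaker inhibitor, a lower number a stronger inhibitor; compound 2 `Cc1ccc(NC(=O)NCC2(c3ccccc3)CCCCC2)cc1` gives 4500 nM; compound 3 `O=C(NCC1(c2ccccc2)CCCCC1)Nc1cccc(Cl)c1Cl` gives 1300 nM. Compound 3 thus stands second of the three: the step of a 4.8-fold higher number from compound 1 to compound 3 (0.68 log units; beyond the scatter) is modest, and the step of a 3.5-fold lower number from compound 2 to compound 3 (0.54 log units; beyond the scatter) is also modest, while a 17-fold higher number from compound 1 to compound 2 (1.22 log units; beyond the scatter) is the large one.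

Compound 4 `O=C(NCC1(c2ccccc2)CCCCC1)Nc1ccc(Cl)c(Cl)c1` is the next case, differing from compound 3 by 3,4-dichlorophenyl in place of 2,3-dichlorophenyl on an amide-type nitrogen. Going by the values given here, no measured step moves chlorines around an otherwise unchanged ring, so the bearing of the known steps is indirect. The steps between compound 1, compound 2 and compound 3 all lie beyond the scatter, and the 4-methylphenyl of compound 2 is the weakest of the three, so a change in this assay of at most modest size, toward a higher number, is expected. The estimate for compound 4 is 2800 nM, with a range from 900 nM to 9000 nM, which would be a step of a 2.2-fold higher number from compound 3 to compound 4 (0.33 log units; beyond the scatter).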

Compound 4, half-maximal inhibitory concentration: 3800 nM
Compound 4: the middle estimate sits 1.4-fold (0.13 log units) below what was measured; measured number inside the range.
By their numbers in this assay, from the lowest: compound 1; then compound 3; then compounds 4 and 2 (each within the scatter of the next).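

Moving the chlorines while keeping the same atoms is not silent in this assay (a 2.9-fold higher number from compound 3 to compound 4 (0.47 log units; beyond the scatter)), so at this position the placement of the substituents matters, not only their identity, at least for the 2,3-dichlorophenyl and 3,4-dichlorophenyl pair. The 3,4-dichlorophenyl group cannot be told apart from the 4-methylphenyl group (a 1.2-fold lower number from compound 2 to compound 4 (0.07 log units; within the scatter)), while the 2-methoxyphenyl group of compound 1 keeps the lowest number of the four (a 14-fold higher number from compound 1 to compound 4 (1.15 log units; beyond the scatter)). Nothing available explains the shift between the two dichlorophenyl groups.

The compounds shown do not separate the effect of the methoxy group from that of its place on the ring, as only the chlorines appear at two different placements. As far as these compounds go, how an amine or a carboxylic acid on the aryl ring would read also remains open.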